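Working notes: the step from compound 3 to compound 4

This account rests on a few compounds, and the source may have more. Where it says the series, first, only, none or still open, it means among the compounds named here.

Measured in a physicochemical assay for lipophilicity, using the shake flask method, measured as octanol-water partition, at pH 7.4; on this read-out higher numbers stand for higher lipophilicity and lower numbers for lower lipophilicity:
- compound 1 `CC(=O)N[C@@H]1CCC[C@H](C(=O)Nc2cc(-c3cnn4c3CCCC4)ccn2)C1` gives 2.4
- compound 2 `CC(=O)N[C@@H]1CCC[C@H](C(=O)Nc2cc(-c3cnn4c3CCCC4)c(F)cn2)C1` gives 2.9
- compound 3 `CC(=O)N[C@@H]1CCC[C@H](C(=O)Nc2cc(-c3cnc4ccccn34)c(Cl)cn2)C1` gives 3

The values of compound 3 and compound 2 lie within the scatter of each other, while the value of compound 3 is higher than that of compound 1 by more than the scatter.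

The next compound is compound 4 `CC(=O)N[C@@H]1CCC[C@H](C(=O)Nc2cc(-c3cnn4c3NCCC4)c(Cl)cn2)C1`, still unmeasured. The change from compound 3 is a group of 9 heavy atoms (6 carbon, 3 nitrogen; one five-membered aromatic ring with 2 hetero atoms, one six-membered non-aromatic ring with 2 hetero atoms) in place of a group of 9 heavy atoms (7 carbon, 2 nitrogen; one five-membered aromatic ring with 2 hetero atoms, one six-membered aromatic ring with 1 hetero atom), on an aromatic carbon. The chloro group stays in place.

For the measured compounds named here, only one measured step is available, a number 0.50 log units higher from compound 1 to compound 2 (beyond the scatter). It is modest and is a swap of fluoro in place of hydrogen on an aromatic carbon, so it does not cover this exchange of groups directly and serves mainly as a guide to size. The group on that carbon in compound 1 (2.4) and compound 2 (2.9) is nearer to the entering group than the group in compound 3 is. These values point to a modest move toward lower numbers, though no direct comparison exists.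

The expected change is a number 0.40 log units lower from compound 3 to compound 4 (beyond the scatter), an estimate of similar size to the measured step. In this assay the estimate for compound 4 is 2.6, with an expected range from 2.2 to 3.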

Compound 4, distribution coefficient: 2.4
Compound 4: the middle estimate sits 0.20 log units above what was measured; measured number inside the range.
By their numbers in this assay, from the lowest: compounds 1 and 4 (each within the scatter of the next); then compounds 2 and 3 (each within the scatter of the next).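

In this assay, for the compounds shown here, the exchange on the aromatic carbon ortho to a chloro group gives the first reading for this position with the chloro group held in place: a number 0.60 log units lower from compound 3 to compound 4 (beyond the scatter). Going by these compounds alone, the only earlier step, fluoro in place of hydrogen, left this group unchanged, whereas here a group with one five-membered aromatic ring and one six-membered non-aromatic ring with 2 hetero atoms, carrying 1 hydrogen-bond donor and 3 hydrogen-bond acceptors, replaces a group with a six-membered aromatic ring with 1 hetero atom and 0 donors and 2 acceptors. No measurement at hand ties the step to any one of these differences between the two groups.

The compounds shown change the ring type and the donor and acceptor counts together, leaving open which of these differences goes with the step. Going by these compounds, a methyl group on the amine nitrogen of the entering group, or an oxygen in place of that nitrogen, would keep the six-membered non-aromatic ring and alter only that atom, and the size of the same exchange with fluoro in place of the chloro group also remains open.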